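Furan in Place of Pyridine: Weak Inhibition Expected Again

The source may report more compounds than this note shows. Statements on the series, on what has been measured and on what is new or still open speak of the compounds shown alone.

Compound 3 `COc1cc(-c2cc(C(=O)O)c3ccccc3n2)ccc1OCC(=O)NCc1cccnc1` shares its core with compound 1 `COc1cc(-c2cc(C(=O)O)c3ccccc3n2)ccc1OCC(=O)Nc1cccc(F)c1` and compound 2 `COc1cc(-c2cc(C(=O)O)c3ccccc3n2)ccc1OCC(=O)NCc1ccccc1`; the three differ only in the group on the amide-type nitrogen. In an ADME assay on HaCaT cells (Homo sapiens) for inhibition (a higher number here means a weaker inhibitor, a lower number a stronger inhibitor), compound 1 gives 148000 nM. For compound 2 the value of > 300000 nM is a limit of the assay, not a number. For compound 3 the value of > 300000 nM is likewise a limit. Compound 3 thus stands at the weak end of what this assay reports, (the limit of > 300000 nM in this assay, at which 2 of the 3 values shown sit). The steps of an at least 2.0-fold higher number from compound 1 to compound 2 (0.30 log units; that floor lies within the scatter) and an at least 2.0-fold higher number from compound 1 to compound 3 (0.30 log units; that floor lies within the scatter) both run toward that edge, while the step that the two limits leave unreadable from compound 2 to compound 3 leaves its size open.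

Compound 4 `COc1cc(-c2cc(C(=O)O)c3ccccc3n2)ccc1OCC(=O)NCc1ccco1` differs from compound 3 by a single change: furan-2-yl in place of pyridin-3-yl on a saturated chain carbon bound to an amide-type nitrogen. Going by the values given here, no measured step covers this swap directly, and the nearest comparison, a step that the two limits leave unreadable from compound 2 to compound 3, cannot be sized. The step of a number no higher from compound 3 to compound 4 (the limit leaves the size open) is therefore expected to show no change beyond the scatter. For compound 4 in this assay the estimate is 300000 nM, within a range from 120000 nM to 700000 nM, quite possibly reported only as a limit.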

Compound 4, half-maximal inhibitory concentration in the HaCaT assay: > 300000 nM
Compound 4: no number, only a limit (the forecaster's own chance of this, stated with the estimate: 60%); the middle value sits exactly at the limit.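

Compound 4 gives a limit, not a number, so furan-2-yl on this saturated chain carbon ends up where phenyl and pyridin-3-yl already stood in the HaCaT assay: the limit of > 300000 nM in the HaCaT assay, at which 3 of the 4 values shown sit. Going by these compounds alone, in the HaCaT assay the one readable step is an at least 2.0-fold higher number from compound 1 to compound 4 (0.30 log units; that floor lies within the scatter), while the steps among compound 2, compound 3 and compound 4 cannot be read. In a physicochemical assay for lipophilicity, using the shake flask method, in phosphate buffer, measured as octanol-water partition, at pH 7.4 (a lower number here means a more polar compound, a higher number a more lipophilic compound), compound 3 gives -0.8 and compound 4 gives -0.3. The swap of pyridin-3-yl for furan-2-yl does register in the physicochemical assay, so this position can change one measured property even while the inhibition read-out stays at its limit: the measured distribution coefficient of compound 3, -0.8, and of compound 4, -0.3, a number 0.50 log units higher (beyond the scatter).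

Left open is whether cyclohexyl or an amine at this place would give a number rather than a limit in the HaCaT assay.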